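Series notes: compound 3 to compound 4 in calcium flux

This account rests on a few compounds, and the source may have more. Where it says the series, first, only, none or still open, it means among the compounds named here.

Compound 3 `Cc1cc(Cc2cccc(F)c2)c(=O)n(CC(=O)Nc2ccc(Br)cc2)n1` gives, in a functional assay on HL-60 cells (Homo sapiens), read by calcium flux (on this read-out higher numbers stand for an effect only at larger amounts of compound and lower numbers for an effect already at smaller amounts), only an assay limit: > 50000 nM. Compound 1 `COc1cccc(Cc2cc(C(C)C)nn(CC(=O)Nc3ccc(Br)cc3)c2=O)c1` likewise shows only a limit, > 50000 nM. Compound 2 `COc1cccc(Cc2cc(C3CCCCC3)nn(CC(=O)Nc3ccc(Br)cc3)c2=O)c1` also stands at a limit, > 50000 nM. Among the compounds with values here, the one step with measured ends, a step that the two limits leave unreadable from compound 1 to compound 2, is therefore not readable, and the limit of > 50000 nM in this assay, at which 3 of the 3 values shown sit, covers every value shown. Compound 4 `Cc1cc(N)c(=O)n(CC(=O)Nc2ccc(Br)cc2)n1` differs from compound 3 by amino in place of 3-fluorobenzyl on an aromatic carbon. Within the data shown here, no measured step bears readably on this change, so no step size can be taken from the series. Compound 4 is expected to reach again only the limit because the limit of > 50000 nM in this assay, at which 3 of the 3 values shown sit, holds throughout. Should a number be returned, compound 4 is estimated at 50000 nM, range 10000 nM to 150000 nM. The expected step of a number no higher from compound 3 to compound 4 (the limit leaves the size open) is none beyond the scatter.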

Compound 4, half-maximal effective concentration: > 50000 nM
Compound 4: only a limit was reported (the forecaster's own chance of this, stated with the estimate: 85%); the middle value lies on the limit itself.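

No step can be read between compound 3 and compound 4, as each gives only a limit in this assay. The compounds shown leave open whether any change to the shared core gives a measurable value in this assay.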